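Ester to pyridinylmethyl amide on the shared core

The compounds below may be only part of what the source reports. "The series", "measured", "known", "first", "only" and "open" are said of these compounds alone.

Two compounds of the series have numbers in an assay on isolated protein for inhibition of Gonadotropin-releasing hormone receptor (Rattus norvegicus); a lower number here means a stronger inhibitor, a higher number a weaker inhibitor. Compound 1 `CCCCCn1c(SCc2cc([N+](=O)[O-])ccc2OC)nc2cc(NC(=O)NC(C)(C)C)ccc21` gives 880 nM in this assay. Compound 2 `CCCn1c(SCc2cc([N+](=O)[O-])ccc2OC)nc2cc(NC(=O)NC(C)(C)C)cc(C(=O)OC)c21` gives 280 nM in this assay, the lowest of the two numbers; the gap to compound 1 lies beyond the scatter, though the two structures differ in more than one place, so the two values are noted without being tied to a single change.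

Compound 3 `CCCn1c(SCc2cc([N+](=O)[O-])ccc2OC)nc2cc(NC(=O)NC(C)(C)C)cc(C(=O)NCc3cccnc3)c21` has not yet been measured. It differs from compound 2 by ((pyridin-3-yl)methyl)amino in place of methoxy on a carbonyl carbon. Going by the values given here, no measured pair shows this change, so the size of the step is open. The expectation is a step of moderate size, a lower number than compound 2, though a result within the scatter would not surprise, and a 1.9-fold lower number from compound 2 to compound 3 (0.27 log units; within the scatter) describes the estimated step. Compound 3 is estimated at 150 nM, with a range from 40 nM to 600 nM.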

Compound 3, half-maximal inhibitory concentration: 54 nM
The estimate for compound 3 lay 2.8-fold (0.44 log units) above the measured number; measured number inside the range.
By their numbers in this assay, from the lowest: compound 3; then compound 2; then compound 1.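

In this assay, going by these compounds alone, the position on the carbonyl carbon responds to the group placed there: ((pyridin-3-yl)methyl)amino in place of methoxy gives a 5.2-fold lower number from compound 2 to compound 3 (0.71 log units; beyond the scatter), the only step that can be read at a single place. The larger group is accepted here, and the number falls beyond the scatter. The change brings in a six-membered aromatic ring with one hetero atom and an amide hydrogen together, and no measurement on hand bears on what lies behind the step.

The compounds shown do not separate the contributions of the ring, its nitrogen and the amide hydrogen; a benzyl amide, a methyl amide or a carboxylic acid on the same carbonyl carbon would address this. Going by these compounds, the pyridin-2-ylmethyl and pyridin-4-ylmethyl amides also remain open.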